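Bromo to hydroxymethyl on the shared core

A few compounds are considered here, and "the series" means these few. Any claim that something is new, unique, unknown or untested is made for them only; others in the source may bear on it.

- Compound 1 `CC1(COc2ccc(OC(F)(F)F)cc2)Cn2cc([N+](=O)[O-])nc2O1`: > 64000 nM, a limit
- Compound 2 `CC1(COc2ccc(OC(F)(F)F)cc2)Cn2ccnc2O1`: > 64000 nM, a limit
- Compound 3 `CC1(COc2ccc(OC(F)(F)F)cc2)Cn2cc(Br)nc2O1`: 34000 nM

Within the data shown here, in an ADME assay on MRC5 cells (Homo sapiens) for cytotoxicity, read by fluorescence, with a stated time of 72 h (on this read-out higher numbers stand for weaker inhibition and lower numbers for stronger inhibition), compound 3 gives the only number, since the other two values are limits. Compound 4 `CC1(COc2ccc(OC(F)(F)F)cc2)Cn2cc(CO)nc2O1` has hydroxymethyl in place of bromo on an aromatic carbon.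

Among the measured compounds shown here, two measured steps bear on this carbon: an at least 1.8-fold lower number from compound 1 to compound 3 (0.27 log units; that floor lies within the scatter) and an at least 1.8-fold lower number from compound 2 to compound 3 (0.27 log units; that floor lies within the scatter). Each floor lies within the scatter. The third step, a step that the two limits leave unreadable from compound 1 to compound 2, cannot be read. Replacing bromo has so far given only (the limit of > 64000 nM in this assay, at which 2 of the 3 values shown sit), so a return towards that limit is expected, though not firmly beyond the scatter. The expected change is a 1.8-fold higher number from compound 3 to compound 4 (0.25 log units; within the scatter). For compound 4 the estimate is 60000 nM, with an expected range of 30000 nM to 110000 nM.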

Compound 4, half-maximal inhibitory concentration: > 64000 nM
Compound 4: only a limit was reported (the forecaster's own chance of this, stated with the estimate: 55%); middle value at least 1.0-fold (0.02 log units) from the limit.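

In this assay, compound 4 also gives only a limit, so bromo remains the only group at this aromatic carbon with a number: the limit of > 64000 nM in this assay, at which 3 of the 4 values shown sit.

Hydroxymethyl in place of bromo gives an at least 1.8-fold higher number from compound 3 to compound 4 (0.27 log units; that floor lies within the scatter). The steps from compound 1 and from compound 2 to compound 4 join two limits and cannot be read.

From the compounds shown here alone, how far the true values of compound 1, compound 2 and compound 4 lie past the limit stays unknown. Going by these compounds, it also stays open whether chloro, an amine or a carboxylic acid at this carbon would give a number in this assay, as bromo does.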